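Turning the drawn stereocentre of compound 3

This account rests on a few compounds, and the source may have more. Where it says the series, first, only, none or still open, it means among the compounds named here.

Compound 3, `CCN(CC)c1nc(Cl)nc(N[C@@H](C)c2ccccc2)n1`, has the lowest number of the three measured compounds in an ADME assay on the whole organism for inhibition, with Oryza sativa as the target, with a stated time of 4 days (a lower number here means a stronger inhibitor, a higher number a weaker inhibitor), giving 380 nM. Compound 2, `CC(C)Nc1nc(Cl)nc(N[C@H](C)c2ccccc2)n1`, gives 5370 nM, and compound 1, `C[C@@H](Nc1nc(Cl)nc(NC(C)(C)C)n1)c1ccccc1`, gives 9330 nM. Within the data shown here, the only single-place step among them, a 1.7-fold lower number from compound 1 to compound 2 (0.24 log units; within the scatter), concerns a change on the saturated chain carbon bound to the ring nitrogen and says nothing about configuration.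

Compound 4, `CCN(CC)c1nc(Cl)nc(N[C@H](C)c2ccccc2)n1`, is the compound to be measured next. Relative to compound 3: the two compounds have the same atoms and bonds and differ only in configuration as drawn: 1 of 1 stereo elements differ; a stereocentre at a saturated chain carbon is drawn S in compound 3 and R in compound 4. Among the measured compounds shown here, no measured step bears on this change alone; compound 2 and compound 4 share the same drawn configuration but differ elsewhere, so their values cannot be separated into a configuration effect and an alkyl effect.

With no measured guide to the size or direction of the step, the expectation for compound 4 is a higher number than compound 3, by a modest step of a 2.9-fold higher number from compound 3 to compound 4 (0.46 log units; beyond the scatter), with a wide range allowed in both directions. In this assay compound 4 is therefore estimated at 1100 nM, between 300 nM and 4500 nM.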

Compound 4, half-maximal inhibitory concentration: 6310 nM
Beside the measured number, compound 4's estimate is 5.7-fold (0.76 log units) below it, and the stated range ends below it.
By their numbers in this assay, from the lowest: compound 3; then compounds 2, 4 and 1 (each within the scatter of the next).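

In this assay, turning the one stereocentre at the saturated chain carbon from S to R comes with a 17-fold higher number from compound 3 to compound 4 (1.22 log units; beyond the scatter), a large step that no earlier pair could show, and it can be assigned to configuration alone: the fact that compounds 3 and 4 differ only in the configuration as drawn

With the drawn configuration of compound 4 held, the amino group makes no difference that can be read: there is a 1.2-fold higher number from compound 2 to compound 4 (0.07 log units; within the scatter), and there is a 1.5-fold lower number from compound 1 to compound 4 (0.17 log units; within the scatter), both within the scatter. Diethylamino alone therefore does not bring the low number of compound 3, since compound 4 carries the same group and its number stays within the scatter of those of compound 1 and compound 2; among these compounds, the low number appears only where diethylamino is paired with the S centre.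

The compounds shown leave open whether turning the centre to S would bring a similar step with isopropylamino or (tert-butyl)amino in place of diethylamino. They also leave open whether the gap between the two configurations would survive a propyl group in place of the methyl on the stereocentre, or a methoxy group in place of the chlorine.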